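The source may hold more compounds than are shown below. What is called first, only, known or untested is meant among the compounds shown, and "the series" means these compounds.

Compound 1 `ClCc1ccc(Cn2cnc3c(Cl)ncnc32)cc1`: > 100000 nM
Compound 2 `ClCc1ccccc1Cn1cnc2c(Cl)ncnc21`: > 100000 nM
Compound 3 `ClCc1ccccc1Cn1cnc2ncnc(Cl)c21`: 83200 nM

All three were tested in a functional assay on K562 cells (Homo sapiens) for cytotoxicity, read by sulforhodamine B assay, with a stated time of 48 h; on this read-out lower numbers stand for higher toxicity in this test and higher numbers for lower toxicity in this test. For compound 1 the value > 100000 nM is a limit of the assay rather than a measured number. The same holds for compound 2, whose value > 100000 nM is also a limit. Only compound 3 gives an actual number, 83200 nM. Compound 1 therefore stands at the limit of > 100000 nM in this assay, at which 2 of the 3 values shown sit; how it compares with compound 3 cannot be read from these values, because one of them is a limit.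

The next compound, compound 4 `ClCc1ccc(Cn2cnc3c(Cl)nc(Cl)nc32)cc1`, differs from compound 1 in one place: chloro in place of hydrogen on an aromatic carbon. Going by the values given here, no measured pair in this set shows the same change, so there is no direct precedent for its effect. With compound 1 at a limit in this assay, the step from compound 1 to compound 4 is expected to be small, a number no higher from compound 1 to compound 4 (the limit leaves the size open), with no clear direction beyond the usual scatter. Compound 4 is therefore expected to give about 100000 nM in this assay, with a range from 30000 nM to 300000 nM.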

Compound 4, concentration lethal to 50% of the cells: > 100000 nM
Compound 4: a limit, no number; the forecaster's own chance of this, stated with the estimate: 60%; the middle value lies on the limit itself.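

In this assay compound 4 gives > 100000 nM, which is a limit and not a number. Compound 1 also sits at a limit, so no step can be read between compound 1 and compound 4. The compounds shown leave open whether chloro in place of hydrogen on an aromatic carbon changes toxicity in this test at all.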